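Swapping 4-aminophenyl for 3,4-dichlorophenyl at the assay limit

The source may report more compounds than this note shows. Statements on the series, on what has been measured and on what is new or still open speak of the compounds shown alone.

- compound 1 `CCOc1ccc(-c2ncnn2-c2cc(OC)c(OC)c(OC)c2)cc1Cl` gives 6 nM
- compound 2 `COc1cc(-c2ncnn2-c2ccc([N+](=O)[O-])cc2)cc(OC)c1OC` gives > 10000 nM
- compound 3 `COc1cc(-c2ncnn2-c2ccc(N)cc2)cc(OC)c1OC` gives > 10000 nM

In a functional assay on HeLa cells (Homo sapiens) for antiproliferative activity, read by MTT assay, with a stated time of 72 h (on this read-out lower numbers stand for stronger inhibition and higher numbers for weaker inhibition), compound 3 gives > 10000 nM as a limit, not a number. Compound 2 gives > 10000 nM as a limit too. Both sit at the limit of > 10000 nM in this assay, at which 2 of the 3 values shown sit, and no number is known for either. Going by the values given here, the one measured step is a step that the two limits leave unreadable from compound 2 to compound 3 and it offers no size to carry forward.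

In this assay, among the compounds with values here, compound 1 reaches 6 nM but it differs from compound 3 in more than one place, so no measured step links them.

Compound 4 `COc1cc(-c2ncnn2-c2ccc(Cl)c(Cl)c2)cc(OC)c1OC` puts 3,4-dichlorophenyl in place of 4-aminophenyl on an aromatic nitrogen and keeps the rest of compound 3. Weak inhibition is expected, since the step that the two limits leave unreadable from compound 2 to compound 3 stayed at the limit on both sides.

In this assay the expected move is an at least 2.0-fold lower number from compound 3 to compound 4 (0.30 log units; that floor lies within the scatter) and it points, if anywhere, to stronger inhibition. For compound 4 the estimate is 5000 nM with an expected range from 700 nM to 10000 nM and a real chance of another limit.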

Compound 4, half-maximal inhibitory concentration: > 10000 nM
Compound 4 was reported as a limit (the forecaster's own chance of this, stated with the estimate: 60%); middle value at least 2.0-fold (0.30 log units) away from the limit.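

Compound 3 and compound 4 each give a limit of the assay rather than a number, so no step between them can be read: the limit of > 10000 nM in this assay, at which 3 of the 4 values shown sit.

The compounds shown leave open which single changes would connect compound 1, the only one with a measured number, to those at the limit.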